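Fluoro in place of chloro: compound 2 to compound 3

The source may hold more compounds than are shown below. What is called first, only, known or untested is meant among the compounds shown, and "the series" means these compounds.

Going by the values given here, in an assay on cells for inhibition of Amine oxidase [flavin-containing] B (Homo sapiens), read by fluorescence and spectrophotometry, using microsomes, with a stated time of 20 min (a lower number here means a stronger inhibitor, a higher number a weaker inhibitor), compound 2 `NS(=O)(=O)c1ccc(-c2nnc(-c3ccc(Cl)cc3)o2)cc1` gives 48 nM, the lowest of the two numbers so far. Among the compounds with values here, its nearest neighbour is compound 1 `N#Cc1ccc(-c2nnc(-c3ccc(S(N)(=O)=O)cc3)o2)cc1`, which in this assay gives 318 nM; the single measured step, a 6.6-fold lower number from compound 1 to compound 2 (0.82 log units; beyond the scatter), shows that the group on this aromatic carbon moves the number by a modest amount. Compound 3 `NS(=O)(=O)c1ccc(-c2nnc(-c3ccc(F)cc3)o2)cc1` keeps everything else and carries fluoro in place of chloro on an aromatic carbon. Within the data shown here, no measured step exchanges one halogen for another, so the cyano-to-chloro step is the only guide, and it bears on the position rather than on the exact change. A step of modest size or none beyond the scatter is therefore expected, with the number more likely to rise than to fall. For compound 3 the estimate is 110 nM, range 40 nM to 350 nM, which means an expected step of a 2.3-fold higher number from compound 2 to compound 3 (0.36 log units; beyond the scatter).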

Compound 3, half-maximal inhibitory concentration: 79 nM
Compound 3: the middle estimate sits 1.4-fold (0.14 log units) above what was measured; the measured number falls inside the stated range.
By their numbers in this assay, from the lowest: compounds 2 and 3 (each within the scatter of the next); then compound 1.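

In this assay, going by these compounds alone, the first exchange of one halogen for another at this position reads a 1.6-fold higher number from compound 2 to compound 3 (0.22 log units; within the scatter), so chloro and fluoro cannot be told apart here. The nitrile now stands apart from both halogens, not just from chloro: alongside the earlier 6.6-fold lower number from compound 1 to compound 2 (0.82 log units; beyond the scatter), fluoro in place of cyano gives a 4.0-fold lower number from compound 1 to compound 3 (0.60 log units; beyond the scatter), and the two halogens share this separation from compound 1. No measurement at hand accounts for this separation.

As far as these compounds go, whether the position keeps these numbers with a bromo group, a methoxy group or an amine remains open, as does the result with only hydrogen on this carbon. Also open, from the compounds shown here alone, is whether the closeness of chloro and fluoro would persist if another part of the shared core were changed.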